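The source may report more compounds than this note shows. Statements on the series, on what has been measured and on what is new or still open speak of the compounds shown alone.

The measured compounds in an ADME assay on Vero cells (Chlorocebus sabaeus) for cytotoxicity, read by CellTiter-Glo, with a stated time of 72 h (on this read-out higher numbers stand for lower toxicity in this test and lower numbers for higher toxicity in this test), are:
compound 1, `[O-][n+]1nc(NC2CCCCC2)[n+]([O-])c2ccccc21`, 8.9 ug/mL
compound 2, `COCC(C)Nc1n[n+]([O-])c2ccccc2[n+]1[O-]`, > 50 ug/mL
compound 3, `[O-][n+]1nc(NC2CCCCC2)[n+]([O-])c2ccc(F)cc21`, < 2.5 ug/mL

The value of compound 2 is a limit of this assay, not a number. The value of compound 3 is likewise a limit. Among the compounds with values here, compound 1 is the one compound of the three with a definite number, and both steps run from it. From compound 1 to compound 2 the change is 1-(methoxymethyl)ethyl in place of cyclohexyl on a nitrogen on an aromatic ring and the step is an at least 5.6-fold higher number from compound 1 to compound 2 (0.74 log units; beyond the scatter). From compound 1 to compound 3 the change is fluoro in place of hydrogen on an aromatic carbon and the step is an at least 3.5-fold lower number from compound 1 to compound 3 (0.55 log units; beyond the scatter). The first step is bounded by the limit of > 50 ug/mL in this assay, at which 1 of the 3 values shown sits, and the second by the limit of < 2.5 ug/mL in this assay, at which 1 of the 3 values shown sits, so only their lower sizes are known.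

Compound 4, `COCC(C)Nc1n[n+]([O-])c2cc(F)ccc2[n+]1[O-]`, is not yet measured. It differs from compound 3 by 1-(methoxymethyl)ethyl in place of cyclohexyl on a nitrogen on an aromatic ring. This is the same change as from compound 1 to compound 2, with the place described in identical words, while the cores of the two pairs differ by fluoro in place of hydrogen on an aromatic carbon. Nothing further is known here about how the fluoro core behaves under this change.

The step from compound 3 to compound 4 is expected to be an at least 6.0-fold higher number from compound 3 to compound 4 (0.77 log units; beyond the scatter). That expectation rests on an at least 5.6-fold higher number from compound 1 to compound 2 (0.74 log units; beyond the scatter), taken as a guide for the same change on the fluoro core. Compound 4 is therefore estimated at 15 ug/mL, between 5 ug/mL and 50 ug/mL.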

Compound 4, half-maximal cytotoxic concentration: 6.3 ug/mL
Compound 4: the middle estimate sits 2.4-fold (0.38 log units) above what was measured, and the stated range covers the measured number.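

In this assay, 1-(methoxymethyl)ethyl in place of cyclohexyl on a nitrogen on an aromatic ring moves the number the same way on the fluoro core as on the core of compound 1, giving an at least 2.5-fold higher number from compound 3 to compound 4 (0.40 log units; beyond the scatter), and the two steps stand side by side as follows: the same change on two cores in this assay, an at least 5.6-fold higher number (0.74 log units; beyond the scatter) from compound 1 to compound 2 and an at least 2.5-fold higher number (0.40 log units; beyond the scatter) from compound 3 to compound 4; the limit leaves it open whether they differ

Read along the other edge of the same set of compounds, fluoro in place of hydrogen on an aromatic carbon also keeps its direction on both side chains, giving an at least 7.9-fold lower number from compound 2 to compound 4 (0.89 log units; beyond the scatter), and those two steps compare as follows: the same change on two cores in this assay, an at least 3.5-fold lower number (0.55 log units; beyond the scatter) from compound 1 to compound 3 and an at least 7.9-fold lower number (0.89 log units; beyond the scatter) from compound 2 to compound 4; the limit leaves it open whether they differ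

The values of compound 2 and compound 3 are both limits and not numbers, so the direction of each change carries from one core to the other here, but only lower sizes are known and nothing shows whether either change is equally large on both cores.

The compounds shown leave open how other groups on that nitrogen would behave, such as a longer chain without the ether oxygen, an open-chain amine or a carboxylic acid. They also leave open whether chloro or methoxy in place of the fluoro would follow the same direction in this assay.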